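The source may hold more compounds than are shown below. What is called first, only, known or untested is meant among the compounds shown, and "the series" means these compounds.

Compound 3 `CC(C)CCn1cnc2c(Nc3ccc(Cl)cc3)nc(N[C@H]3CC[C@H](N)CC3)nc21` carries the lowest number shown in a functional assay on K562 cells (Homo sapiens) for inhibition, read by fluorescence, with a stated time of 72 h (a higher number here means a weaker inhibitor of growth, a lower number a stronger inhibitor of growth), at 1800 nM, though its gap to compound 2 lies within the scatter. Among the measured compounds shown here, compound 2 `CC(C)CCn1cnc2c(NCc3cccc(Cl)c3)nc(N[C@H]3CC[C@H](N)CC3)nc21` gives 3100 nM in this assay, and the one single-place step among the measured compounds, a 1.7-fold lower number from compound 2 to compound 3 (0.24 log units; within the scatter), is small. Compound 1 `CCCCCCn1cnc2c(Nc3ccc(O)cc3)nc(N[C@H]3CC[C@H](N)CC3)nc21` gives 5400 nM in this assay; it differs from compound 3 in more than one place, so only the two values themselves are known. Compound 4 `CC(C)CCn1cnc2c(Nc3cccc(O)c3)nc(N[C@H]3CC[C@H](N)CC3)nc21` carries 3-hydroxyphenyl in place of 4-chlorophenyl on a nitrogen on an aromatic ring. For the measured compounds named here, no measured step covers this change; the only step available concerns a different place and stayed within the scatter. A modest rise is therefore expected, with the step of a 1.9-fold higher number from compound 3 to compound 4 (0.29 log units; within the scatter). Compound 4 is estimated at 3500 nM, between 1500 nM and 8000 nM.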

Compound 4, concentration for 50% growth inhibition: 7600 nM
For compound 4 the middle estimate is 2.2-fold (0.34 log units) below the measured one, and the stated range covers the measured number.
By their numbers in this assay, from the lowest: compounds 3, 2, 1 and 4 (each within the scatter of the next, the first and the last beyond it).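

At this position, on a nitrogen on an aromatic ring, 3-hydroxyphenyl in place of 4-chlorophenyl gives a step beyond the scatter in this assay (a 4.2-fold higher number from compound 3 to compound 4 (0.63 log units; beyond the scatter)), whereas the earlier step at this place stayed within it. The step with 3-chlorobenzyl as the group replaced also lies beyond the scatter (a 2.5-fold higher number from compound 2 to compound 4 (0.39 log units; beyond the scatter)). Nothing available accounts for these rises.

The compounds shown leave open how a plain phenyl, or a phenyl carrying an amine, would read at this nitrogen. They also cannot separate the exchange of chlorine for hydroxyl from the shift in its place on the ring.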